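This account rests on a few compounds, and the source may have more. Where it says the series, first, only, none or still open, it means among the compounds named here.

Compound 1, `Cc1nc(-c2ccccc2)c(C(=O)N2CCN(c3cccc(C#N)c3)CC2)o1`: 39.6 nM
Compound 2, `Cc1nc(-c2ccccc2Cl)c(C(=O)N2CCN(c3cccc(Cl)c3)CC2)o1`: 132 nM
Compound 3, `Cc1nc(-c2cccc(OP(=O)(O)O)c2)c(C(=O)N2CCN(c3cccc(Cl)c3)CC2)o1`: > 1000 nM

All three share one core and were tested in a functional assay on HL-60 cells (Homo sapiens) for inhibition, read by MTT assay, with a stated time of 72 h; a higher number here means a weaker inhibitor, a lower number a stronger inhibitor. Compound 1 gives 39.6 nM. Compound 2 gives 132 nM. For compound 3 no number is known: the result is only a limit, > 1000 nM, and compound 3 stands at the limit of > 1000 nM in this assay, at which 1 of the 3 values shown sits, the edge of what this assay reports. Nothing measured so far joins any two of these compounds by a single change, so no step between them can be read off.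

Compound 4, `Cc1nc(-c2ccccc2)c(C(=O)N2CCN(c3cccc(Cl)c3)CC2)o1`, differs from compound 3 in one place: a hydrogen atom in place of a group of 5 heavy atoms (4 oxygen, 1 phosphorus; no ring), on an aromatic carbon. Compound 4 therefore carries the same chlorine-bearing ring on the piperazine side as compound 3 but no longer the phosphorus-containing group.

In this assay a large step toward a lower number, well beyond the usual scatter, is expected, because compound 1 without such a group gives 39.6 nM and compound 2 without it gives 132 nM. Compound 3, which carries the group, reaches only a limit. Compound 4 is expected to give about 60 nM, within 20 nM to 200 nM. This estimate means an expected step of an at least 16-fold lower number from compound 3 to compound 4 (1.22 log units; beyond the scatter) in this assay.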

Compound 4, half-maximal inhibitory concentration: 39.2 nM
Compound 4: middle estimate off by 1.5-fold (0.18 log units), on the high side; the measured number falls inside the stated range.
By their numbers in this assay, from the lowest: compounds 4 and 1 (each within the scatter of the next); then compound 2. At a limit, above all of these: compound 3.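

Compound 3 is held only as a limit in this assay: the limit of > 1000 nM in this assay, at which 1 of the 4 values shown sits.

Even so, the step read against that limit is large, an at least 25-fold lower number from compound 3 to compound 4 (1.40 log units; beyond the scatter), and it comes from one change: a hydrogen atom in place of the group of 5 heavy atoms (4 oxygen, 1 phosphorus) on an aromatic carbon, so this is the first direct sign that the group goes with a much weaker result in this assay and that low numbers here do not need it. Compound 4 also links the two other compounds by single changes: hydrogen in place of chloro on an aromatic carbon gives a modest step, a 3.4-fold lower number from compound 2 to compound 4 (0.53 log units; beyond the scatter), while chloro in place of cyano on an aromatic carbon gives a 1.0-fold lower number from compound 1 to compound 4 (0.00 log units; within the scatter), which lies within the scatter, so these two groups cannot be told apart here.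

For the compounds shown here, only one group has been compared with hydrogen at the carbon that carries the phosphorus-containing group, so it stays open whether a smaller group there, such as a hydroxyl, a methoxy or an amine, would behave like hydrogen or like that group. From the compounds shown here alone, the full size of the step to compound 4 also stays open, since one end of it is only a limit.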